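From 2-bromobenzyl to 4-fluorobenzyl on a shared core

The source may hold more compounds than are shown below. What is called first, only, known or untested is meant among the compounds shown, and "the series" means these compounds.

Compound 1 `N#Cc1ccc(Nc2nccc(OCc3ccc(Cl)cc3)n2)cc1` gives 156000 nM
Compound 2 `N#Cc1ccc(Nc2nccc(OCc3ccccc3Br)n2)cc1` gives 130000 nM

Among the measured compounds shown here, in an ADME assay on MT4 cells (Homo sapiens) for cytotoxicity, read by MTT assay, with a stated time of 5 days (a lower number here means that less compound is tolerated, a higher number that more compound is tolerated), compound 2 gives 130000 nM, which lies within the scatter of compound 1 at 156000 nM, the only other measured compound. Compound 3 `N#Cc1ccc(Nc2nccc(OCc3ccc(F)cc3)n2)cc1` is not yet measured. It carries 4-fluorophenyl in place of 2-bromophenyl on a saturated chain carbon bound to an oxygen on an aromatic ring. For the measured compounds named here, the only measured step bearing on this change sits at the same place, a 1.2-fold lower number from compound 1 to compound 2 (0.08 log units; within the scatter), so no step beyond the scatter is expected in this assay. The expected step is a 1.1-fold higher number from compound 2 to compound 3 (0.03 log units; within the scatter). Compound 3 is estimated at 140000 nM, with a range of 70000 nM to 280000 nM.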

Compound 3, half-maximal cytotoxic concentration: 81000 nM
For compound 3 the middle estimate is 1.7-fold (0.24 log units) above the measured one; measured number inside the range.
By their numbers in this assay, from the lowest: compounds 3, 2 and 1 (each within the scatter of the next).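

With 4-fluorophenyl in place of 2-bromophenyl on the saturated chain carbon, this assay gives a 1.6-fold lower number from compound 2 to compound 3 (0.21 log units; within the scatter). Fluoro in place of chloro on an aromatic carbon gives a 1.9-fold lower number from compound 1 to compound 3 (0.28 log units; within the scatter), so this assay does not separate the three halogen-bearing benzyl groups on the shared core, now including a change of halogen alone. No supporting measurement offers an explanation for these results. As far as these compounds go, whether a benzyl group carrying an amine or a carboxylic acid, or a longer chain at this place, would stay within the same scatter remains open.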